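A few compounds are considered here, and "the series" means these few. Any claim that something is new, unique, unknown or untested is made for them only; others in the source may bear on it.

Measured compounds in an ADME assay on blood (Homo sapiens) for pharmacokinetics; a lower number here means that the compound disappears faster, a higher number that the compound lasts longer:
- compound 1 `COC(=O)CCNC(=O)[C@@H]1O[P@@](=O)(OCOC(=O)c2ccns2)OCC1(C)C` gives < 0.16 h; this is a limit of the assay.
- compound 2 `COC(=O)CCNC(=O)[C@@H]1O[P@](=O)(OCOC(=O)c2ocnc2C)OCC1(C)C` gives 0.27 h.
- compound 3 `COC(=O)CCNC(=O)[C@@H]1O[P@@](=O)(OCOC(=O)c2cc(C(C)(C)C)n[nH]2)OCC1(C)C` gives > 1 h; this too is a limit of the assay.

Compound 3 thus sits at the upper limit of this assay, beyond both other values shown. Among the measured compounds shown here, the only measured step is an at least 6.2-fold higher number from compound 1 to compound 3 (0.79 log units; beyond the scatter). Compound 4 `COC(=O)CCNC(=O)[C@@H]1O[P@@](=O)(OCOC(=O)c2ocnc2C)OCC1(C)C` has not been measured; it differs from compound 3 by 4-methyl-1,3-oxazol-5-yl in place of 3-(tert-butyl)-1H-pyrazol-5-yl on a carbonyl carbon. Compound 2 carries the same 4-methyl-1,3-oxazol-5-yl group on its carbonyl carbon, and its value of 0.27 h suggests a shorter half-life than compound 3. A drop is therefore expected, an at least 3.3-fold lower number from compound 3 to compound 4 (0.52 log units; beyond the scatter), and compound 4 is estimated at 0.3 h, between 0.15 h and 0.7 h.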

Compound 4, half-life: 0.52 h
The estimate for compound 4 lay 1.7-fold (0.24 log units) below the measured number, within the range that was stated.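

In this assay, 4-methyl-1,3-oxazol-5-yl on this carbonyl carbon gives an at least 3.2-fold higher number from compound 1 to compound 4 (0.51 log units; beyond the scatter), a clear separation from 1,2-thiazol-5-yl, while the change from 3-(tert-butyl)-1H-pyrazol-5-yl gives an at least 1.9-fold lower number from compound 3 to compound 4 (0.28 log units; that floor lies within the scatter), so no real loss is established. Both steps rest on a limit of the assay, held by compound 1 in the first and compound 3 in the second. The stereocentre at phosphorus gives a 1.9-fold higher number from compound 2 to compound 4 (0.28 log units; within the scatter), so this pair shows no separable effect of configuration.

Still open, from the compounds shown here alone, is the true half-life of compound 3, whose value is only a limit. Also open, going by these compounds, is how an amine or a carboxylic acid at this place would behave.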